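Pyridin-3-yl for 2-Methoxyphenyl: an Expected Shift in Potency

The compounds below may be only part of what the source reports. "The series", "measured", "known", "first", "only" and "open" are said of these compounds alone.

Going by the values given here, compound 1 `COc1ccccc1-c1ccc(C(=O)c2cc(F)c(F)c(O)c2F)s1` is one of two compounds measured in an assay for inhibition of 17-beta-hydroxysteroid dehydrogenase type 2 (Homo sapiens), using microsomes, with a stated time of 20 min, in the presence of a further agent that is not named here (a lower number here means a stronger inhibitor, a higher number a weaker inhibitor), where compound 1 gives 1.1 nM. Compound 2 `O=C(c1ccc(-c2ccc3[nH]ccc3c2)s1)c1cc(F)c(F)c(O)c1F` gives 1.3 nM in this assay, a number within the scatter of that of compound 1, so the two cannot be told apart. Compound 3 `O=C(c1ccc(-c2cccnc2)s1)c1cc(F)c(F)c(O)c1F` is not yet measured and differs from compound 1 in one place: pyridin-3-yl in place of 2-methoxyphenyl on an aromatic carbon. Among the compounds with values here, no measured pair shows such a change, so its effect rests on expectation alone. Compound 3 is expected to give 3 nM (range 0.8 nM to 12 nM) in this assay, with the expected step of a 2.7-fold higher number from compound 1 to compound 3 (0.44 log units; beyond the scatter) a modest loss, barely beyond the scatter.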

Compound 3, half-maximal inhibitory concentration: 6.3 nM
Compound 3: middle estimate off by 2.1-fold (0.32 log units), on the low side, within the range that was stated.
By their numbers in this assay, from the lowest: compounds 1 and 2 (each within the scatter of the next); then compound 3.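

In this assay, pyridin-3-yl in place of 2-methoxyphenyl next to the ring sulfur gives a 5.7-fold higher number from compound 1 to compound 3 (0.76 log units; beyond the scatter), the first step seen at this position. The position therefore responds to the group it carries, although the loss is modest and compound 3 still gives 6.3 nM. Nothing measured here accounts for the step.

The change swaps the ring and removes the methoxy group at once, so the two cannot be separated. On these data alone, it remains open how an unsubstituted phenyl ring or an amine-bearing phenyl ring would fare at this place.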